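Amide substituent swaps and cytotoxicity in MT4 cells

The compounds below may be only part of what the source reports. "The series", "measured", "known", "first", "only" and "open" are said of these compounds alone.

Measured so far in an ADME assay on MT4 cells (Homo sapiens) for cytotoxicity, read by MTT assay; on this read-out lower numbers stand for higher toxicity in this test and higher numbers for lower toxicity in this test:
compound 1 `Cc1cc(C)cc(S(=O)(=O)c2c(C(=O)Nc3ccccc3O)[nH]c3ccc(Cl)cc23)c1` gives 19700 nM;
compound 2 `Cc1cc(C)cc(S(=O)(=O)c2c(C(=O)Nc3ccc(O)cc3)[nH]c3ccc(Cl)cc23)c1` gives 18100 nM;
compound 3 `Cc1cc(C)cc(S(=O)(=O)c2c(C(=O)NCc3ccccc3O)[nH]c3ccc(Cl)cc23)c1` gives 23800 nM.

Compound 2 has the smallest number of the three, but its neighbours lie close: a 1.1-fold lower number from compound 1 to compound 2 (0.04 log units; within the scatter) and a 1.3-fold higher number from compound 2 to compound 3 (0.12 log units; within the scatter). The unmeasured compound 4 `Cc1cc(C)cc(S(=O)(=O)c2c(C(=O)NC(C)c3ccccc3O)[nH]c3ccc(Cl)cc23)c1` differs from compound 2 by a group of 9 heavy atoms (8 carbon, 1 oxygen; one six-membered aromatic ring of carbon only) in place of a group of 7 heavy atoms (6 carbon, 1 oxygen; one six-membered aromatic ring of carbon only), on an amide-type nitrogen. For the measured compounds named here, two measured steps bear on this: a 1.1-fold lower number from compound 1 to compound 2 (0.04 log units; within the scatter), which moves the hydroxy group on the ring, and a 1.3-fold higher number from compound 2 to compound 3 (0.12 log units; within the scatter), which inserts one carbon between ring and nitrogen; a 1.2-fold higher number from compound 1 to compound 3 (0.08 log units; within the scatter) combines both. None left the scatter, so in this assay no step beyond the scatter is expected for compound 4. The estimate for compound 4 is 21000 nM, between 10000 nM and 45000 nM, meaning an expected 1.2-fold higher number from compound 2 to compound 4 (0.06 log units; within the scatter).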

Compound 4, half-maximal cytotoxic concentration: 21800 nM
For compound 4 the middle estimate is 1.0-fold (0.02 log units) below the measured one; the measured number falls inside the stated range.
By their numbers in this assay, from the lowest: compounds 2, 1, 4 and 3 (each within the scatter of the next).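

In this assay the methyl on the saturated chain carbon bound to the amide-type nitrogen and the aromatic carbon adds no step beyond the scatter (a 1.1-fold lower number from compound 3 to compound 4 (0.04 log units; within the scatter)). The larger group on the amide-type nitrogen likewise stays within the scatter of both hydroxyphenyl compounds (a 1.2-fold higher number from compound 2 to compound 4 (0.08 log units; within the scatter); a 1.1-fold higher number from compound 1 to compound 4 (0.04 log units; within the scatter)). No measurement here gives a reason for this flat result.

An amine or a carboxylic acid on the chain carbon, or a longer chain there, could behave differently. So could the same swaps on another part of the shared core.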